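A Trimethoxyphenyl Replaces a Nitrophenyl on the Shared Core

The source may hold more compounds than are shown below. What is called first, only, known or untested is meant among the compounds shown, and "the series" means these compounds.

Three compounds built on one shared core were tested in a functional assay on A549 cells (Homo sapiens) for inhibition, read by sulforhodamine B assay, tested at 100 uM; on this read-out lower numbers stand for less inhibition of growth and higher numbers for more inhibition of growth at the one concentration tested. Compound 1 `COc1cc(C2CC(c3ccc(OCc4cn(Cc5ccc([N+](=O)[O-])cc5)nn4)cc3)=NN2C(C)=O)ccc1Oc1cn(Cc2ccc([N+](=O)[O-])cc2)nn1` gives 42% in this assay. Compound 2 `COc1ccc(C2CC(c3ccc(OCc4cn(Cc5ccc([N+](=O)[O-])cc5)nn4)cc3)=NN2C(C)=O)cc1` gives 33%. Compound 3 `COc1cc(C2CC(c3ccc([N+](=O)[O-])cc3)=NN2C(C)=O)ccc1OCc1cn(Cc2ccc([N+](=O)[O-])cc2)nn1` gives 72%, the highest of the three numbers: compound 1 stands nearest to it, with a number lower by an amount beyond the usual scatter, and compound 2 stands furthest, again beyond the scatter.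

Compound 4 `COc1cc(C2CC(c3cc(OC)c(OC)c(OC)c3)=NN2C(C)=O)ccc1OCc1cn(Cc2ccc([N+](=O)[O-])cc2)nn1` has not yet been measured. It differs from compound 3 by 3,4,5-trimethoxyphenyl in place of 4-nitrophenyl on a carbon with a double bond to nitrogen. Among the compounds with values here, no pair of the measured compounds differs in this one place, so the size of this step has no precedent among them. Because compound 3 gives 72% while the other two lie well below it, a downward step of a number 22 percentage points lower from compound 3 to compound 4 (beyond the scatter) is expected, beyond the scatter but leaving clear inhibition. Compound 4 is therefore estimated at 50%, with a range from 25% to 78%.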

Compound 4, percent growth inhibition at one concentration: 85%
The estimate for compound 4 lay 35 percentage points below the measured number, outside the stated range (above it).
By their numbers in this assay, from the lowest: compounds 2 and 1 (each within the scatter of the next); then compound 3; then compound 4.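

In this assay, within the data shown here, the exchange of 4-nitrophenyl for 3,4,5-trimethoxyphenyl on the carbon with a double bond to nitrogen gives a number 13 percentage points higher from compound 3 to compound 4 (beyond the scatter) and is the only single-place step read at this position. It shows that growth inhibition at this position does not depend on keeping the 4-nitrophenyl group: a phenyl ring carrying three methoxy groups and no nitro group serves at least as well, with a modest gain. No measurement here accounts for this rise.

The compounds shown leave open whether all three methoxy groups are needed, and where a plain phenyl, a 4-methoxyphenyl or a 4-aminophenyl on this carbon would fall relative to compound 3 and compound 4. They also leave open whether the same exchange would give a step of similar size on the other compounds of the series.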